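The source may hold more compounds than are shown below. What is called first, only, known or untested is meant among the compounds shown, and "the series" means these compounds.

Compound 1 `COc1ccc(-c2c(C)nc(S)n2Nc2cccc(Cl)c2)cc1` and compound 2 `COC(=O)C1C(C)N=C(S)N1Nc1cccc(Cl)c1` share a core and the same anilino substituent, and both were tested in a functional assay on MT4 cells (Homo sapiens) for cytotoxicity; on this read-out higher numbers stand for lower toxicity in this test and lower numbers for higher toxicity in this test. In this assay compound 1 gives 38700 nM, while compound 2 gives 190000 nM. On these two numbers compound 1 stands lowest, and the gap to compound 2 lies beyond the usual scatter of the test, so compound 1 is the more toxic of the pair.

The step under consideration leads from compound 1 to compound 3 `Cc1nc(S)n(Nc2cccc(Cl)c2)c1-c1ccc(Cl)cc1`. The change is chloro in place of methoxy on an aromatic carbon. Among the measured compounds shown here, no measured pair in this set isolates this particular exchange, so the expectation rests on the position of compound 1 alone.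

For the step from compound 1 to compound 3, the change is expected to be a 1.3-fold lower number from compound 1 to compound 3 (0.11 log units; within the scatter), that is, nothing beyond the scatter, with a slight lean toward a lower number. Compound 3 is therefore expected to give about 30000 nM in this assay, within a range from 12000 nM to 80000 nM.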

Compound 3, half-maximal cytotoxic concentration: 40800 nM
For compound 3 the middle estimate is 1.4-fold (0.13 log units) below the measured one; the range from low to high includes it.
By their numbers in this assay, from the lowest: compounds 1 and 3 (each within the scatter of the next); then compound 2.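

Replacing methoxy with chloro on an aromatic carbon of the six-membered aromatic ring, para to a large group, gives a 1.1-fold higher number from compound 1 to compound 3 (0.02 log units; within the scatter) in this assay, so the two compounds cannot be told apart on this read-out. Among the compounds shown here, the earlier compounds offered no pair that differed in one place, and this step is the first reading of any single exchange: at this position, the hydrogen-bond acceptor counted on methoxy can be lost, and chloro can enter, with no shift beyond the scatter in this test. Nothing available explains why the two substituents read alike here.

This single exchange does not show whether the same would hold for quite different groups at this position, such as an amine, a carboxylic acid or a longer alkyl chain. It also leaves open whether methoxy and chloro would still read alike if the anilino substituent or another part of the shared core were changed.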